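The source may hold more compounds than are shown below. What is called first, only, known or untested is meant among the compounds shown, and "the series" means these compounds.

Measured so far in a functional assay on BCG823 cells (Homo sapiens) for antiproliferative activity, read by MTT assay, with a stated time of 48 h; on this read-out lower numbers stand for stronger inhibition and higher numbers for weaker inhibition

- Compound 1 `O=c1cc(-c2ccccc2)oc2cc(OCc3ccccc3)c(OCCCCN3CCCCC3)c(O)c12` gives 3000 nM
- Compound 2 `CN1CCN(CCCOc2c(OCc3ccccc3)cc3oc(-c4ccccc4)cc(=O)c3c2O)CC1` gives 4100 nM
- Compound 3 `COc1cc2oc(-c3ccccc3)cc(=O)c2c(O)c1OCCCN1CCN(C)CC1` gives 31300 nM

Two steps show where compound 2 stands, namely a 1.4-fold higher number from compound 1 to compound 2 (0.14 log units; within the scatter) and then a 7.6-fold higher number from compound 2 to compound 3 (0.88 log units; beyond the scatter) in this set. It therefore lies within the scatter of compound 1, while the number for compound 3 is higher by a margin beyond the scatter.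

Compound 4 `O=c1cc(-c2ccccc2)oc2cc(OCc3ccccc3)c(OCCCCN3CCCC3)c(O)c12` has not yet been measured. The change leading to it from compound 2 is (pyrrolidin-1-yl)methyl in place of 4-methylpiperazin-1-yl on a saturated chain carbon, three bonds along the chain from an oxygen on an aromatic ring and it places (pyrrolidin-1-yl)methyl where 4-methylpiperazin-1-yl stood, on a saturated chain carbon, three bonds along the chain from an oxygen on an aromatic ring. Read one bond further out, 3-(4-methylpiperazin-1-yl)propyl gives way to 4-(pyrrolidin-1-yl)butyl.

The closest guide is a 1.4-fold higher number from compound 1 to compound 2 (0.14 log units; within the scatter) for a swap at this same place, and it stayed within the scatter. The larger step, a 7.6-fold higher number from compound 2 to compound 3 (0.88 log units; beyond the scatter) for hydrogen in place of phenyl, does not apply, as compound 4 keeps that phenyl. No change beyond the scatter is therefore expected in this assay and the expected size is a 1.2-fold lower number from compound 2 to compound 4 (0.07 log units; within the scatter) for this swap. For compound 4 the estimated value is 3500 nM with an expected range from 1500 nM to 8000 nM in this test.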

Compound 4, half-maximal inhibitory concentration: 3200 nM
Beside the measured number, compound 4's estimate is 1.1-fold (0.04 log units) above it; measured number inside the range.
By their numbers in this assay, from the lowest: compounds 1, 4 and 2 (each within the scatter of the next); then compound 3.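

In this assay, among the compounds shown here, the new result gives the first swap that changes only the ring at the end of the 4-carbon-named butyl chain, with a 1.1-fold higher number from compound 1 to compound 4 (0.03 log units; within the scatter) for pyrrolidin-1-yl in place of piperidin-1-yl on a saturated chain carbon, four bonds along the chain from an oxygen on an aromatic ring. It also adds a second comparison with the 3-(4-methylpiperazin-1-yl)propyl group, with a 1.3-fold lower number from compound 2 to compound 4 (0.11 log units; within the scatter) for the move to 4-(pyrrolidin-1-yl)butyl, so that three different chain-and-amine ends now lie within the scatter of one another and none of the compounds 1, 2 and 4 goes against this. Nothing given here explains why these numbers stay so close.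

The step from compound 2 to compound 4 alters the chain and the ring together, so the compounds shown cannot separate the two, and a morpholine ring, an open dimethylamino end or a longer pentyl chain could still depart from this flat picture. Going by these compounds, whether a carboxylic acid at the chain end would fall within the same scatter also remains open.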